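The source may report more compounds than this note shows. Statements on the series, on what has been measured and on what is new or still open speak of the compounds shown alone.

Measured compounds:
Compound 1, `COc1ccc(-n2c(S)nnc2-c2cc(OC)c(OC)c(OC)c2)cc1`: > 60000 nM (a limit)
Compound 2, `COc1ccc(-n2c(SCC(=O)c3ccc(OC)c(O)c3)nnc2-c2cc(OC)c(OC)c(OC)c2)cc1`: > 60000 nM (a limit)
Compound 3, `CCSc1nnc(-c2cc(OC)c(OC)c(OC)c2)n1-c1ccc(N(C)C)cc1`: 46200 nM

In a functional assay on PC-3 cells (Homo sapiens) for inhibition, read by MTT assay, with a stated time of 48 h (on this read-out lower numbers stand for stronger inhibition and higher numbers for weaker inhibition), compound 1 reaches only a limit, > 60000 nM. Compound 2 likewise stops at a limit, > 60000 nM. Going by the values given here, compound 3 gives 46200 nM, the only number among the three. The values of compound 1 and compound 2 are limits, so compound 3 cannot be ranked against them. Among the compounds with values here, the single step between measured compounds, a step that the two limits leave unreadable from compound 1 to compound 2, cannot be read, since both of its ends sit at the limit of > 60000 nM in this assay, at which 2 of the 3 values shown sit.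

Compound 4, `COc1cc(-c2nnc(SCC(=O)Nc3ccc(Cl)cc3)n2-c2ccc(N(C)C)cc2)cc(OC)c1OC`, differs from compound 3 in one place: (4-chlorophenyl)carbamoyl in place of methyl on a saturated chain carbon bound to a sulfur. No measured step bears on this change; the only measured step is unreadable, so the size and direction of the coming step are not supported by anything shown. The estimate therefore keeps compound 4 close to compound 3 with a wide range. In this assay compound 4 is expected at about 35000 nM, between 9000 nM and 140000 nM. The step this estimate implies, a 1.3-fold lower number from compound 3 to compound 4 (0.12 log units; within the scatter), is expected to stay within the scatter.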

Compound 4, half-maximal inhibitory concentration: > 60000 nM
Compound 4: a limit, no number (the forecaster's own chance of this, stated with the estimate: 40%); at least 1.7-fold (0.23 log units) between middle value and limit.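

On the saturated chain carbon bound to a sulfur, (4-chlorophenyl)carbamoyl in place of methyl gives, in this assay, an at least 1.2-fold higher number from compound 3 to compound 4 (0.11 log units; that floor lies within the scatter). The floor of this step lies within the scatter, and the value of compound 4 is a limit, so this change is not shown to reduce inhibition, although it also yields no number of its own at this position. Compound 3 thus remains the only compound with a number, and compound 4 adds one more limit to the set: the limit of > 60000 nM in this assay, at which 3 of the 4 values shown sit.

As far as these compounds go, whether a carboxylic acid or a longer alkyl chain on that same carbon would give a number in this assay stays open. Also open is how the carbamoyl part and the 4-chlorophenyl part each bear on the result, since the compounds shown carry them only together.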